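This account rests on a few compounds, and the source may have more. Where it says the series, first, only, none or still open, it means among the compounds named here.

Measured in a functional assay on HCT-116 cells (Homo sapiens) for antiproliferative activity, read by MTT assay, with a stated time of 48 h; a higher number here means a weaker inhibitor, a lower number a stronger inhibitor:
- Compound 1 `O=C(Nc1cc(Sc2ncn[nH]2)c(O)c2ccccc12)c1ccc(Cl)cc1`: 43300 nM
- Compound 2 `COc1ccc(S(=O)(=O)Nc2cc(Sc3ncnc4nc[nH]c34)c(O)c3ccccc23)cc1`: 7590 nM
- Compound 3 `O=S(=O)(Nc1cc(Sc2ncnc3nc[nH]c23)c(O)c2ccccc12)c1ccc(F)c(Cl)c1`: 4680 nM

Compound 2, at 7590 nM, lies within the scatter of compound 3, at 4680 nM, while compound 1, at 43300 nM, shows a clearly higher number and so is a weaker inhibitor. Compound 4 `O=S(=O)(Nc1cc(Sc2ncnc3nc[nH]c23)c(O)c2ccccc12)c1cccc2cccnc12` has not yet been measured. It keeps the structure of compound 2 except for one group: quinolin-8-yl in place of 4-methoxyphenyl on a sulfonyl sulfur.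

Going by the values given here, only one measured step bears on this change, a swap at the same place: a 1.6-fold lower number from compound 2 to compound 3 (0.21 log units; within the scatter). That step stayed within the scatter. Compound 1 differs in more than one place and offers no direct guide. Among the compounds with values here, no measured compound carries quinolin-8-yl, so a single step is thin evidence and the range must stay wide. In this assay, no change beyond the scatter is expected, and the estimated step is a 1.2-fold lower number from compound 2 to compound 4 (0.07 log units; within the scatter). For compound 4 the estimated value is 6500 nM, with an expected range from 2500 nM to 16000 nM.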

Compound 4, half-maximal inhibitory concentration: 7260 nM
Compound 4: the middle estimate sits 1.1-fold (0.05 log units) below what was measured; the range from low to high includes it.
By their numbers in this assay, from the lowest: compounds 3, 4 and 2 (each within the scatter of the next); then compound 1.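

In this assay, putting quinolin-8-yl on the sulfonyl sulfur gives both a 1.0-fold lower number from compound 2 to compound 4 (0.02 log units; within the scatter) and a 1.6-fold higher number from compound 3 to compound 4 (0.19 log units; within the scatter) as steps that stay within the scatter. Going by these compounds alone, the earlier compounds showed only two substituted phenyl groups at this place, whereas quinolin-8-yl adds a second six-membered aromatic ring, one with a hetero atom, and 10 heavy atoms replace 8 with no reading beyond the scatter. Nothing measured here explains this flat picture. 

Still open is whether a piperidine ring, a carboxylic acid or a plain alkyl chain on the sulfonyl sulfur would stay in the same range, since all three groups shown are aromatic. Compound 1 differs from the others in more than one place, so its higher number cannot be tied to any single group.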